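From compound 1 to compound 3: one added methyl

The source may report more compounds than this note shows. Statements on the series, on what has been measured and on what is new or still open speak of the compounds shown alone.

compound 1 `COc1cc(/C=C\c2ccc3[nH]ccc3c2)cc(OC)c1`: 700 nM
compound 2 `COc1cc(/C=C\c2ccc3[nH]cnc3c2)cc(OC)c1`: 1000 nM

Going by the values given here, both compounds have been measured in a functional assay on SNU-423 cells (Homo sapiens) for cytotoxicity, read by resazurin assay, with a stated time of 48 h; on this read-out lower numbers stand for stronger inhibition and higher numbers for weaker inhibition. In this assay compound 1 gives 700 nM, and compound 2 gives 1000 nM. Among the compounds with values here, these two values lie within the usual scatter of each other, so compound 1 stands level with the only other compound measured so far.

Compound 3 `COc1cc(/C=C\c2ccc3c(ccn3C)c2)cc(OC)c1` keeps the core of compound 1 and differs in one place: methyl in place of hydrogen on an aromatic nitrogen. This is methyl in place of hydrogen on an aromatic nitrogen. Within the data shown here, no measured pair shows this change, so the data give no direct guide to its effect. In this assay no step beyond the scatter is expected, and the estimate starts from compound 1 at 700 nM. The expected change is a 1.1-fold higher number from compound 1 to compound 3 (0.06 log units; within the scatter). For compound 3 the estimated value is 800 nM, with an expected range from 250 nM to 2500 nM.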

Compound 3, half-maximal inhibitory concentration: 30 nM
The estimate for compound 3 lay 27-fold (1.43 log units) above the measured number; measured number outside the range, below it.
By their numbers in this assay, from the lowest: compound 3; then compounds 1 and 2 (each within the scatter of the next).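

In this assay methyl in place of hydrogen on an aromatic nitrogen gives a 23-fold lower number from compound 1 to compound 3 (1.37 log units; beyond the scatter) and so makes a large step beyond the scatter. Going by these compounds alone, compound 1 and compound 2 had stood level with each other, so this is the first sign that a single change can move the number this far, and that the aromatic nitrogen of the five-membered aromatic ring is a place where one added carbon matters. Nothing at hand accounts for the size of this step.

Still open, going by these compounds, is whether the drop belongs to methyl alone or carries over to a larger group on the same nitrogen, such as ethyl, a longer chain or a chain ending in an amine. Also open, on these data alone, is whether the same change on compound 2 would give a step of similar size.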